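A few compounds are considered here, and "the series" means these few. Any claim that something is new, unique, unknown or untested is made for them only; others in the source may bear on it.

Measured so far:
compound 1, `CC(C)Cn1c(=O)n(C)c(=O)c2c1ncn2C`: 19000 nM
compound 2, `CCCn1cnc2c1c(=O)n(C)c(=O)n2CC(C)C`: 13000 nM

For the measured compounds named here, in an assay on cell membranes with adenosine receptor A1 (Rattus norvegicus) as the target (on this read-out lower numbers stand for stronger inhibition and higher numbers for weaker inhibition), compound 2 and compound 1 stand within the scatter of each other; the only measured step, a 1.5-fold lower number from compound 1 to compound 2 (0.16 log units; within the scatter), is within the scatter. Compound 3, `C=CCn1cnc2c1c(=O)n(C)c(=O)n2CC(C)C`, differs from compound 2 by vinyl in place of ethyl on a saturated chain carbon bound to an aromatic nitrogen. Going by the values given here, no measured step covers this change; the one known step concerns a different change at that saturated chain carbon bound to an aromatic nitrogen and was within the scatter. No step beyond the scatter is therefore expected. Compound 3 is estimated at 11000 nM, range 4000 nM to 30000 nM. The expected step of a 1.2-fold lower number from compound 2 to compound 3 (0.07 log units; within the scatter) stays within the scatter.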

Compound 3, inhibition constant: 13000 nM
Beside the measured number, compound 3's estimate is 1.2-fold (0.07 log units) below it, and the stated range covers the measured number.
By their numbers in this assay, from the lowest: compounds 2, 3 and 1 (each within the scatter of the next).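

In this assay, vinyl in place of ethyl on a saturated chain carbon bound to an aromatic nitrogen gives no change at the digits printed from compound 2 to compound 3 (within the scatter), so adding a double bond outside aromatic rings does not separate the two compounds. The second new step, a 1.5-fold lower number from compound 1 to compound 3 (0.16 log units; within the scatter), also lies within the scatter, and hydrogen, ethyl and vinyl at this carbon remain undistinguished on this read-out. No measured evidence bears on this result. Open, as far as these compounds go, is whether an amine, a carboxylic acid or a longer chain at this place would give a step beyond the scatter.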